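Relocating the Trifluoromethyl Group: Two Parallel Changes

This account rests on a few compounds, and the source may have more. Where it says the series, first, only, none or still open, it means among the compounds named here.

Compound 1 `Oc1ccccc1-c1cc(-c2ccccc2C(F)(F)F)cc(-c2ccccc2O)n1` gives 4770 nM in a functional assay on DU-145 cells (Homo sapiens) for inhibition; a lower number here means a stronger inhibitor, a higher number a weaker inhibitor.
Compound 2 `Oc1ccccc1-c1cc(-c2cccc(C(F)(F)F)c2)cc(-c2ccccc2O)n1` reaches only a limit of the assay, > 50000 nM.
Compound 3 `Oc1cccc(-c2cc(-c3ccccc3C(F)(F)F)cc(-c3ccccc3O)n2)c1` gives 7250 nM.

The step of an at least 10-fold higher number from compound 1 to compound 2 (1.02 log units; beyond the scatter) arises from the change (3-(trifluoromethyl)phenyl in place of 2-(trifluoromethyl)phenyl on an aromatic carbon); the value of compound 2 sits at the assay limit (the limit of > 50000 nM in this assay, at which 1 of the 3 values shown sits). The core of compound 3 differs from that of compound 1 by 3-hydroxyphenyl in place of 2-hydroxyphenyl on an aromatic carbon, a step of a 1.5-fold higher number from compound 1 to compound 3 (0.18 log units; within the scatter). Compound 4 `Oc1cccc(-c2cc(-c3cccc(C(F)(F)F)c3)cc(-c3ccccc3O)n2)c1`, not yet measured, carries the same kind of change, (3-(trifluoromethyl)phenyl in place of 2-(trifluoromethyl)phenyl on an aromatic carbon); here the place is meta to a 2-hydroxyphenyl group and meta to a 3-hydroxyphenyl group, whereas in compound 1 it is meta to two 2-hydroxyphenyl groups. Because compound 1 showed an at least 10-fold higher number from compound 1 to compound 2 (1.02 log units; beyond the scatter), a similar step is expected from compound 3: a 12-fold higher number from compound 3 to compound 4 (1.09 log units; beyond the scatter). Compound 4 is thus estimated at 90000 nM, between 30000 nM and 300000 nM, most probably reported only as a limit.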

Compound 4, half-maximal inhibitory concentration: 13000 nM
Compound 4: middle estimate off by 6.9-fold (0.84 log units), on the high side; the measured number lies below the stated range.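

In this assay, the change to 3-(trifluoromethyl)phenyl gives a 1.8-fold higher number from compound 3 to compound 4 (0.25 log units; within the scatter), so the large step seen on the core of compound 1 does not carry over to the core of compound 3: the same change on two cores in this assay, an at least 10-fold higher number (1.02 log units; beyond the scatter) from compound 1 to compound 2 and a 1.8-fold higher number (0.25 log units; within the scatter) from compound 3 to compound 4, at least 5.8-fold (0.76 log units) apart, beyond the scatter of two such steps. The change to 3-hydroxyphenyl likewise depends on the core, giving an at least 3.8-fold lower number from compound 2 to compound 4 (0.58 log units; beyond the scatter), and so the two changes do not act independently in these four compounds: the same change on two cores in this assay, a 1.5-fold higher number (0.18 log units; within the scatter) from compound 1 to compound 3 and an at least 3.8-fold lower number (0.58 log units; beyond the scatter) from compound 2 to compound 4, at least 5.8-fold (0.76 log units) apart, beyond the scatter of two such steps. The value of compound 2 is only a limit, so both gaps are minimum sizes, and four compounds show no rule for the wider series: the limit of > 50000 nM in this assay, at which 1 of the 4 values shown sits.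

The compounds shown leave open whether this dependence on the core persists when a methoxy group or an amine replaces the hydroxyl groups. On these data alone, it is also open whether it holds when a chlorine atom or a nitrile replaces the trifluoromethyl group.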